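Replacing a Pyrrolidine Urea with a Plain Alkyl Chain

The compounds below may be only part of what the source reports. "The series", "measured", "known", "first", "only" and "open" are said of these compounds alone.

Compound 1 `CC(C)(C)C(=O)N1CCC[C@H]1C(=O)N1CCC(NS(=O)(=O)c2cc(S(=O)(=O)c3ccccc3)ccc2C(F)(F)F)CC1`: 40 nM
Compound 2 `CN(C)CC(=O)N1CCC[C@H]1C(=O)N1CCC(NS(=O)(=O)c2cc(S(=O)(=O)c3ccccc3)ccc2C(F)(F)F)CC1`: 90 nM
Compound 3 `CC(C)(C)NC(=O)N1CCC[C@H]1C(=O)N1CCC(NS(=O)(=O)c2cc(S(=O)(=O)c3ccccc3)ccc2C(F)(F)F)CC1`: 20 nM

All three share one core and differ only in the group on the carbonyl carbon. In an assay on isolated protein for binding affinity to secreted frizzled-related protein 1 (Homo sapiens), read by fluorescence (on this read-out higher numbers stand for weaker inhibition and lower numbers for stronger inhibition), compound 3 gives the lowest of the three numbers, although compound 1 sits within the scatter of it. The steps seen are a 2.0-fold lower number from compound 1 to compound 3 (0.30 log units; within the scatter), a 2.3-fold higher number from compound 1 to compound 2 (0.35 log units; beyond the scatter) and a 4.5-fold lower number from compound 2 to compound 3 (0.65 log units; beyond the scatter). Compound 4 `CC(C)(C)CCN1CCC[C@H]1C(=O)N1CCC(NS(=O)(=O)c2cc(S(=O)(=O)c3ccccc3)ccc2C(F)(F)F)CC1` makes a different kind of change: 3,3-dimethylbutyl in place of (tert-butyl)carbamoyl on an amine nitrogen in a ring. Among the measured compounds shown here, no measured step removes the carbonyl itself, so the earlier steps bear on this only loosely; they show that even modest swaps here move the number, the largest being a 4.5-fold lower number from compound 2 to compound 3 (0.65 log units; beyond the scatter). A somewhat higher number is therefore expected. Compound 4 is estimated at 60 nM, with a range from 15 nM to 250 nM. The expected step is a 3.0-fold higher number from compound 3 to compound 4 (0.48 log units; beyond the scatter).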

Compound 4, half-maximal inhibitory concentration: 30 nM
Estimate against measurement, compound 4: 2.0-fold (0.30 log units) above; the measured number falls inside the stated range.
By their numbers in this assay, from the lowest: compounds 3, 4 and 1 (each within the scatter of the next); then compound 2.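

In this assay, 3,3-dimethylbutyl on the amine nitrogen in a ring removes the carbonyl altogether, yet a 1.5-fold higher number from compound 3 to compound 4 (0.18 log units; within the scatter) and a 1.3-fold lower number from compound 1 to compound 4 (0.12 log units; within the scatter) both stay within the scatter, so these compounds do not need that carbonyl to keep their numbers. Among the compounds shown here, the one step beyond the scatter is a 3.0-fold lower number from compound 2 to compound 4 (0.48 log units; beyond the scatter) and it leads to a lower number, so losing the carbonyl does not by itself weaken binding here. No measured evidence on the reason for this is at hand.

As far as these compounds go, whether a plain chain must be this size stays open, since a shorter ethyl group, a longer octyl chain and a chain ending in a carboxylic acid could each behave differently on this nitrogen.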